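Trading trifluoromethyl for fluoro on compound 3

The compounds below may be only part of what the source reports. "The series", "measured", "known", "first", "only" and "open" are said of these compounds alone.

In a functional assay on RPMI-8226 cells (Homo sapiens) for cytotoxicity, read by MTT assay, with a stated time of 48 h (on this read-out lower numbers stand for stronger inhibition and higher numbers for weaker inhibition), compound 1 `C#CCOC(=O)NN=C1C(Cl)=C(Cl)C(Cl)=C1Cl` gives 800 nM and compound 2 `O=C(c1ccccc1)N(N=C1C(Cl)=C(Cl)C(Cl)=C1Cl)C(=O)c1ccccc1` gives 800 nM. Compound 3 `FC(F)(F)c1cccc(NN=C2C(Cl)=C(Cl)C(Cl)=C2Cl)c1` stands lowest of the three at 110 nM, and its gap to each of the other two lies beyond the usual scatter. Compound 4 `Fc1cccc(NN=C2C(Cl)=C(Cl)C(Cl)=C2Cl)c1` has not yet been measured in this assay. It carries fluoro in place of trifluoromethyl on an aromatic carbon, and the change counts as fluoro in place of trifluoromethyl on an aromatic carbon. Going by the values given here, no measured pair shows a change of this kind, so the expectation is tentative. A modest weakening, a little beyond the scatter, is expected, with an estimated step of a 2.3-fold higher number from compound 3 to compound 4 (0.36 log units; beyond the scatter). For compound 4 the estimated value is 250 nM, with an expected range of 70 nM to 800 nM.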

Compound 4, half-maximal inhibitory concentration: 500 nM
The estimate for compound 4 lay 2.0-fold (0.30 log units) below the measured number, and the stated range covers the measured number.
By their numbers in this assay, from the lowest: compound 3; then compounds 4, 1 and 2 (each within the scatter of the next).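

Fluoro in place of trifluoromethyl on this aromatic carbon gives, in this assay, the only step that can be read at this position: a 4.5-fold higher number from compound 3 to compound 4 (0.66 log units; beyond the scatter). This shows that the position responds to the change, with trifluoromethyl giving the lower number of the pair. Nothing at hand explains the size or direction of this step.

The compounds shown leave open how a methoxy, an amine or a carboxylic acid would read at this place. They also leave open whether this step would recur with the group on another ring carbon.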